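Exchanging Acetyl for Cyano on Compound 2

A few compounds are considered here, and "the series" means these few. Any claim that something is new, unique, unknown or untested is made for them only; others in the source may bear on it.

Of the compounds shown here, three built on one shared core have been tested in a functional assay on K562 cells (Homo sapiens) for inhibition, read by sulforhodamine B assay, with a stated time of 48 h; on this read-out lower numbers stand for stronger inhibition of growth and higher numbers for weaker inhibition of growth. Compound 1 `CCOC(=O)C(=Cc1c(-c2ccccc2)[nH]c2ccccc12)C(=O)OCC` gives 3600 nM. Compound 2 `CC(=O)/C(=C\c1c(-c2ccccc2)[nH]c2ccccc12)S(=O)(=O)c1ccccc1` gives 442 nM, and compound 3 `COc1ccc(-c2[nH]c3ccc(OC)cc3c2C=C(C#N)C#N)cc1` gives 345 nM. Compound 2 thus holds the second highest of the three numbers: its nearest neighbour is compound 3, which sits within the scatter of it, while compound 1 lies furthest away with the higher number, a gap beyond the scatter.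

Compound 4 `N#C/C(=C\c1c(-c2ccccc2)[nH]c2ccccc12)S(=O)(=O)c1ccccc1` has not yet been measured. It differs from compound 2 in one place: cyano in place of acetyl on a double-bonded chain carbon bound to a double-bonded chain carbon and a sulfonyl sulfur. Among the measured compounds shown here, no step between measured compounds isolates this exchange, so its effect is uncertain. Compound 3, which carries cyano groups, is nonetheless within the scatter of compound 2, and the expected step in this assay is a 1.1-fold lower number from compound 2 to compound 4 (0.02 log units; within the scatter), none beyond the scatter in either direction. Compound 4 is therefore estimated at 420 nM, with a range from 150 nM to 1200 nM.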

Compound 4, concentration for 50% growth inhibition: 348 nM
Estimate against measurement, compound 4: 1.2-fold (0.08 log units) above, within the range that was stated.
By their numbers in this assay, from the lowest: compounds 3, 4 and 2 (each within the scatter of the next); then compound 1.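

Among the compounds shown here, this exchange is the first that can be read on its own: in this assay, cyano in place of acetyl at this place gives a 1.3-fold lower number from compound 2 to compound 4 (0.10 log units; within the scatter). The step shows that, with the sulfonyl sulfur held constant, the acetyl group can give way to cyano on this double-bonded chain carbon with no change beyond the scatter. No measurement of any property of the two groups accompanies this result.

The compounds shown leave open how other groups at this place, such as a carboxylic acid, an amine or a longer chain, would read. They also leave open whether cyano would behave alike when the sulfonyl group on the same carbon gives way to an ethyl ester.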